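From 1H-imidazol-4-yl to thiophen-3-yl on a shared core

The source may hold more compounds than are shown below. What is called first, only, known or untested is meant among the compounds shown, and "the series" means these compounds.

Three compounds that share one core and differ in a single group have been measured in a functional assay on HeLa S3 cells (Homo sapiens) for cytotoxicity, read by XTT assay, with a stated time of 3 days; on this read-out higher numbers stand for weaker inhibition and lower numbers for stronger inhibition. Compound 1 `OC[C@H]1O[C@@H](n2cc(F)c3c(-c4ccccc4)ncnc32)[C@H](O)[C@@H]1O`, which carries phenyl, gives 2600 nM, and compound 2 `OC[C@H]1O[C@@H](n2cc(F)c3c(-c4nccs4)ncnc32)[C@H](O)[C@@H]1O`, which carries 1,3-thiazol-2-yl, gives 3100 nM. The step between these two is a 1.2-fold higher number from compound 1 to compound 2 (0.08 log units; within the scatter). Compound 3 `OC[C@H]1O[C@@H](n2cc(F)c3c(-c4c[nH]cn4)ncnc32)[C@H](O)[C@@H]1O`, which carries 1H-imidazol-4-yl, gives 12200 nM, the highest number of the three and so the weakest inhibition. Two measured steps lead to it: a 4.7-fold higher number from compound 1 to compound 3 (0.67 log units; beyond the scatter), and a 3.9-fold higher number from compound 2 to compound 3 (0.59 log units; beyond the scatter).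

The next compound, compound 4 `OC[C@H]1O[C@@H](n2cc(F)c3c(-c4ccsc4)ncnc32)[C@H](O)[C@@H]1O`, has thiophen-3-yl in place of 1H-imidazol-4-yl on an aromatic carbon. Among the measured compounds, 1H-imidazol-4-yl is the one group that stands apart, and the two other groups both gave lower numbers. Read backwards, the steps to compound 3 therefore suggest a modest fall in the number when this group leaves, of similar size or slightly larger. For the measured compounds named here, this rests on only three compounds, and none of them carries thiophen-3-yl. The expected change is a 6.1-fold lower number from compound 3 to compound 4 (0.79 log units; beyond the scatter). Compound 4 is estimated at 2000 nM, with an expected range from 300 nM to 6500 nM.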

Compound 4, half-maximal inhibitory concentration: 210 nM
Compound 4: the middle estimate sits 9.5-fold (0.98 log units) above what was measured; the measured number lies below the stated range.
By their numbers in this assay, from the lowest: compound 4; then compounds 1 and 2 (each within the scatter of the next); then compound 3.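

For the compounds shown here, compound 4 shows that this position can do far more than the earlier compounds suggested: they pointed only to a weaker result with 1H-imidazol-4-yl, while thiophen-3-yl gives a clearly lower number than either of the two better earlier groups (a 15-fold lower number from compound 2 to compound 4 (1.17 log units; beyond the scatter); a 12-fold lower number from compound 1 to compound 4 (1.09 log units; beyond the scatter)). Going by these compounds alone, the direct exchange is the largest step so far (a 58-fold lower number from compound 3 to compound 4 (1.76 log units; beyond the scatter)), although both groups have 5 heavy atoms in a five-membered aromatic ring, so in these two compounds ring size and heavy-atom count do not set the result; the exchange does swap the ring atoms and remove the hydrogen-bond donor, but this single pair cannot show which of those differences matters. Nothing available here accounts for the size of this gain.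

The compounds shown leave open whether the low number belongs to thiophen-3-yl in particular, since closely related rings such as thiophen-2-yl or furan-3-yl would be needed to test how exact the match must be. On these data alone, it also remains open whether adding a small substituent to the thiophene ring, such as a methyl group or an amine, would keep, improve or lose this result.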